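Sulfonyl aryl swap in a weakly active series

The source may report more compounds than this note shows. Statements on the series, on what has been measured and on what is new or still open speak of the compounds shown alone.

Compound 2 `CCOC(=O)c1oc2ccc(N(Cc3ccccc3)S(=O)(=O)c3cccc(Cl)c3)cc2c1C` reaches only the limit of a functional assay on HCT-116 cells (Homo sapiens) for inhibition, read by MTT assay, with a stated time of 72 h (a lower number here means a stronger inhibitor, a higher number a weaker inhibitor), giving > 40000 nM. Compound 1 `CCOC(=O)c1oc2ccc(N(Cc3ccccc3)S(=O)(=O)c3ccc(C(F)(F)F)cc3)cc2c1C`, carrying 4-(trifluoromethyl)phenyl on the sulfonyl sulfur, gives 26700 nM in this assay; the step of an at least 1.4-fold higher number from compound 1 to compound 2 (0.17 log units; that floor lies within the scatter) is bounded by the limit of > 40000 nM in this assay, at which 1 of the 2 values shown sits. Compound 3 `CCOC(=O)c1oc2ccc(N(Cc3ccccc3)S(=O)(=O)c3ccc(F)cc3)cc2c1C` differs from compound 2 by 4-fluorophenyl in place of 3-chlorophenyl on a sulfonyl sulfur. For the measured compounds named here, only that single step bears on this change, and its floor lies within the scatter, so no step beyond the scatter is expected in this assay. Compound 3 is estimated at 40000 nM, between 15000 nM and 100000 nM. The expected step of a number no higher from compound 2 to compound 3 (the limit leaves the size open) stays within the scatter.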

Compound 3, half-maximal inhibitory concentration: 5820 nM
Compound 3: the middle estimate sits 6.9-fold (0.84 log units) above what was measured; the measured number lies below the stated range.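

In this assay, the aryl group on the sulfonyl sulfur can shift the number beyond the scatter: 4-fluorophenyl in place of 3-chlorophenyl gives an at least 6.8-fold lower number from compound 2 to compound 3 (0.83 log units; beyond the scatter), and fluoro in place of trifluoromethyl on an aromatic carbon gives a 4.6-fold lower number from compound 1 to compound 3 (0.66 log units; beyond the scatter). Compound 3 therefore stands as the strongest inhibitor of the three. The first step is only a floor, set by a limit of the assay: the limit of > 40000 nM in this assay, at which 1 of the 3 values shown sits.

The compounds shown do not separate the change of halogen from the change in its printed ring number, which 4-chlorophenyl or 3-fluorophenyl would address. Going by these compounds, how an aminophenyl group would behave on the sulfonyl sulfur also remains open.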